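Carbonyl added to the sulfanyl side chain

The source may report more compounds than this note shows. Statements on the series, on what has been measured and on what is new or still open speak of the compounds shown alone.

Measured in a functional assay on PC-3 cells (Homo sapiens) for inhibition, read by MTT assay, with a stated time of 48 h (a lower number here means a stronger inhibitor, a higher number a weaker inhibitor), so far
- compound 1 `CCSc1nnc(-c2cc(OC)c(OC)c(OC)c2)n1-c1ccc(N(C)C)cc1` gives 46200 nM here
- compound 2 `COc1cc(-c2nnc(SCc3ccc(F)cc3)n2-c2ccc(N(C)C)cc2)cc(OC)c1OC` gives 46500 nM here

Among the compounds with values here, compound 2 stands within the scatter of compound 1, the only other measured compound. Compound 3 `COc1cc(-c2nnc(SCC(=O)c3ccc(F)cc3)n2-c2ccc(N(C)C)cc2)cc(OC)c1OC` carries (4-fluorophenyl)carbonyl in place of 4-fluorophenyl on a saturated chain carbon bound to a sulfur. Within the data shown here, the single measured step at this place is flat (a 1.0-fold higher number from compound 1 to compound 2 (0.00 log units; within the scatter)), so no step beyond the scatter is expected in this assay for this change. Among the measured compounds shown here, that support is thin, and no measured compound carries this carbonyl. The expected step is small (a 1.2-fold lower number from compound 2 to compound 3 (0.07 log units; within the scatter)). Compound 3 is estimated at 40000 nM (expected range 12000 nM to 100000 nM).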

Compound 3, half-maximal inhibitory concentration: 42300 nM
Estimate against measurement, compound 3: 1.1-fold (0.02 log units) below; low and high end bracket the measured number.
By their numbers in this assay, from the lowest: compounds 3, 1 and 2 (each within the scatter of the next).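

In this assay the (4-fluorophenyl)carbonyl group on a saturated chain carbon bound to a sulfur stays within the scatter of both 4-fluorophenyl (a 1.1-fold lower number from compound 2 to compound 3 (0.04 log units; within the scatter)) and methyl (a 1.1-fold lower number from compound 1 to compound 3 (0.04 log units; within the scatter)). Adding a carbonyl, with its hydrogen-bond acceptor, to the side chain therefore gives no readable step, and all three side chains now sit at one level. Nothing available explains this flat result.
Still open, going by these compounds, is whether an amine, a carboxylic acid or a longer chain at this place would give a step beyond the scatter.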